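Swapping the ring-nitrogen substituent in a phenylsulfanyl series

The compounds below may be only part of what the source reports. "The series", "measured", "known", "first", "only" and "open" are said of these compounds alone.

Measured compounds:
- compound 1, `CN1CCC(Oc2ccc(Nc3ncc4nc([S+]([O-])c5ccccc5)n(C5CCOCC5)c4n3)cc2)CC1`, 853 nM
- compound 2, `CN1CCN(c2ccc(Nc3ncc4nc([S+]([O-])c5ccccc5)n([C@H]5CC[C@H](O)CC5)c4n3)cc2)CC1`, 268 nM
- compound 3, `CN1CCN(c2ccc(Nc3ncc4nc(Sc5ccccc5)n([C@H]5CC[C@H](O)CC5)c4n3)cc2)CC1`, 42.6 nM

The read-out is a functional assay on HCC827 cells (Homo sapiens) for antiproliferative activity, read by MTT assay, with a stated time of 72 h; a higher number here means a weaker inhibitor, a lower number a stronger inhibitor. For the measured compounds named here, compound 3 stands lowest of the three numbers, and its steps to both others are beyond the scatter, so it is the most potent compound measured so far. Going by the values given here, the one single-point step known is a 6.3-fold lower number from compound 2 to compound 3 (0.80 log units; beyond the scatter), where the phenylsulfanyl group replaced a phenylsulfinyl group.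

Compound 4, `CN1CCN(c2ccc(Nc3ncc4nc(Sc5ccccc5)n(C5CC5)c4n3)cc2)CC1`, changes a different part of compound 3: cyclopropyl in place of 4-hydroxycyclohexyl on an aromatic nitrogen. Among the compounds with values here, none of the measured steps touches this ring-nitrogen substituent, so nothing measured bears directly on the change, and the direction cannot be read from the data. Compound 4 is therefore expected to land near compound 3, with a wide range to reflect the lack of guidance, giving an estimated 1.9-fold higher number from compound 3 to compound 4 (0.27 log units; within the scatter). The estimate for compound 4 is 80 nM, between 20 nM and 320 nM.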

Compound 4, half-maximal inhibitory concentration: 305 nM
Compound 4: the middle estimate sits 3.8-fold (0.58 log units) below what was measured; the measured number falls inside the stated range.
By their numbers in this assay, from the lowest: compound 3; then compounds 2 and 4 (each within the scatter of the next); then compound 1.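

The ring-nitrogen substituent clearly matters: in this assay, with the rest of the molecule unchanged, replacing 4-hydroxycyclohexyl with cyclopropyl gives a 7.2-fold higher number from compound 3 to compound 4 (0.85 log units; beyond the scatter). That step is similar in size to the one from swapping phenylsulfinyl for phenylsulfanyl, a 6.3-fold lower number from compound 2 to compound 3 (0.80 log units; beyond the scatter), so this position affects the number about as much as that group does. No measurement here explains the weaker result, and this single change alters the ring size and removes the hydroxyl group together.

A plain cyclohexyl group on this nitrogen would help separate those two changes, while a 4-aminocyclohexyl group would show whether another substituent can stand in for the hydroxyl group. On these data alone, it also remains open whether the same substituent change would have a similar effect with phenylsulfinyl in place of phenylsulfanyl.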